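A few compounds are considered here, and "the series" means these few. Any claim that something is new, unique, unknown or untested is made for them only; others in the source may bear on it.

Measured so far:
compound 1, `CC[C@@H]1/C=C(\C)C[C@H](C)C[C@H](OC)[C@H]2O[C@@](O)(C(=O)C(=O)N3CCCC[C@H]3C(=O)O[C@H](/C(C)=C/[C@@H]3CC[C@@H](Oc4ccc(N(C)C)cc4)[C@H](OC)C3)[C@H](C)[C@@H](O)CC1=O)[C@H](C)C[C@@H]2OC`, in a functional assay on cells for inhibition, with Murine T-cell line (Mus musculus) as the target (a higher number here means a weaker inhibitor, a lower number a stronger inhibitor), gives 1.1 nM;
compound 2, `CC[C@@H]1/C=C(\C)C[C@H](C)C[C@H](OC)[C@H]2O[C@@](O)(C(=O)C(=O)N3CCCC[C@H]3C(=O)O[C@H](/C(C)=C/[C@@H]3CC[C@@H](Oc4ccc(OC)cc4)[C@H](OC)C3)[C@H](C)[C@@H](O)CC1=O)[C@H](C)C[C@@H]2OC`, in this assay gives 1.4 nM.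

Compound 2 has the higher of the two numbers, but its gap to compound 1, a 1.3-fold higher number from compound 1 to compound 2 (0.10 log units; within the scatter), is within the scatter, so the two cannot be told apart. Compound 3, `CC[C@@H]1/C=C(\C)C[C@H](C)C[C@H](OC)[C@H]2O[C@@](O)(C(=O)C(=O)N3CCCC[C@H]3C(=O)O[C@H](/C(C)=C/[C@@H]3CC[C@@H](Oc4cccc(OC)c4)[C@H](OC)C3)[C@H](C)[C@@H](O)CC1=O)[C@H](C)C[C@@H]2OC`, differs from compound 2 only in the aromatic group: 3-methoxyphenyl in place of 4-methoxyphenyl on an oxygen on a saturated carbon. Among the compounds with values here, the one measured step, from compound 1 to compound 2, exchanges one group for another on that ring and bears only loosely on this change, which keeps the same atoms and rearranges them. Within the data shown here, with no direct precedent, the expectation for the step from compound 2 to compound 3 is a 1.8-fold higher number from compound 2 to compound 3 (0.25 log units; within the scatter), an estimated small weakening that may well fall within the scatter. Compound 3 is therefore expected to give about 2.5 nM in this assay, with a plausible range from 1 nM to 8 nM.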

Compound 3, half-maximal inhibitory concentration: 3.4 nM
Estimate against measurement, compound 3: 1.4-fold (0.13 log units) below, within the range that was stated.
By their numbers in this assay, from the lowest: compounds 1 and 2 (each within the scatter of the next); then compound 3.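

In this assay, exchanging 4-methoxyphenyl for 3-methoxyphenyl with the same atoms gives a 2.4-fold higher number from compound 2 to compound 3 (0.39 log units; beyond the scatter), a modest step but one beyond the scatter. The exchange of 4-(dimethylamino)phenyl for 3-methoxyphenyl likewise gives a 3.1-fold higher number from compound 1 to compound 3 (0.49 log units; beyond the scatter), so this position, where compound 1 and compound 2 could not be told apart, does respond to the aromatic group, though compound 3 still gives 3.4 nM in the low nanomolar range. No measurement is at hand that would explain this step.

The compounds shown leave open whether 3-(dimethylamino)phenyl would differ from 4-(dimethylamino)phenyl as the methoxy pair does. They also leave open how an unsubstituted phenyl, or a phenyl carrying a carboxylic acid or a longer alkoxy chain, would read in this assay at this oxygen.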